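This account rests on a few compounds, and the source may have more. Where it says the series, first, only, none or still open, it means among the compounds named here.

Measured values in a functional assay on MCF7 cells (Homo sapiens) for cytotoxicity, read by MTT assay, with a stated time of 96 h; on this read-out higher numbers stand for weaker inhibition and lower numbers for stronger inhibition:
compound 1 (`COc1cc(C(=O)c2cn(-c3ccccc3)cc2-c2ccc(N)cc2)cc(OC)c1OC`): 9 nM
compound 2 (`COc1cc(C(=O)c2cn(-c3ccccc3[N+](=O)[O-])cc2-c2ccccc2)cc(OC)c1OC`): 5000 nM
compound 3 (`COc1cc(C(=O)c2cn(-c3cccc([N+](=O)[O-])c3)cc2-c2ccccc2)cc(OC)c1OC`): 550 nM

Compound 3 holds the second highest of the three numbers, with compound 2 at 5000 nM above it and compound 1 at 9 nM below it. Compound 4 (`COc1cc(C(=O)c2cn(-c3cc(OC)c(OC)c(OC)c3)cc2-c2ccccc2)cc(OC)c1OC`) differs from compound 3 as follows: 3,4,5-trimethoxyphenyl in place of 3-nitrophenyl on an aromatic nitrogen in all. Among the compounds with values here, only one measured step bears on this change, a 9.1-fold lower number from compound 2 to compound 3 (0.96 log units; beyond the scatter) on the same aromatic nitrogen. It swaps one nitrophenyl for another, so it shows that this place can move the number but gives no direction for 3,4,5-trimethoxyphenyl. A step of similar or smaller size is therefore expected in this assay with its direction open. For compound 4 the estimated value is 700 nM with an expected range from 130 nM to 3500 nM in this assay. This estimate means an expected 1.3-fold higher number from compound 3 to compound 4 (0.10 log units; within the scatter) overall.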

Compound 4, half-maximal inhibitory concentration: > 5000 nM
Compound 4 was reported as a limit; the forecaster's own chance of this, stated with the estimate: 10%; middle value at least 7.1-fold (0.85 log units) from the limit.
By their numbers in this assay, from the lowest: compound 1; then compound 3; then compound 2.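

In this assay, the earlier step only exchanged one nitrophenyl for another, whereas 3,4,5-trimethoxyphenyl on the aromatic nitrogen gives an at least 9.0-fold higher number from compound 3 to compound 4 (0.95 log units; beyond the scatter), so the first change away from a nitrophenyl moves toward weaker inhibition. Compound 4 stands as a limit, not a number: the limit of > 5000 nM in this assay, at which 1 of the 4 values shown sits.

The remaining step reads only as a number no lower from compound 2 to compound 4 (the limit leaves the size open), so its size cannot be read. Open, from the compounds shown here alone, is how a methyl or benzyl group on this nitrogen would read, and whether one methoxy group on the phenyl would give the same result as three.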